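A few compounds are considered here, and "the series" means these few. Any claim that something is new, unique, unknown or untested is made for them only; others in the source may bear on it.

Among the compounds with values here, in an ADME assay on microsomes from liver (Mus musculus, strain CD-1) for metabolic stability, read by LC-MS, tested at 2 uM (on this read-out higher numbers stand for a longer-lived compound and lower numbers for a shorter-lived compound), three related compounds have numbers so far. Compound 1 `Cn1ccc2ccc(-c3cc(Nc4ccccc4S(=O)(=O)N4CCOCC4)cc4nccnc34)cc21` gives 0.367 h as its half-life, compound 2 `CN1CCCC(NS(=O)(=O)c2ccccc2Nc2cc(-c3ccc4ccn(C)c4c3)c3nccnc3c2)C1` gives 0.483 h on the same read-out, and compound 3 `CC(=O)N1CCC(NC(=O)c2ccncc2Nc2cc(-c3ccc4ccn(C)c4c3)c3nccnc3c2)CC1` gives 0.117 h and stands lowest of the three, with its gaps to both others beyond the scatter. Compared with compound 3, the still unmeasured compound 4 `Cn1ccc2ccc(-c3cc(Nc4cnccc4C(=O)NCC4COCCN4)cc4nccnc34)cc21` carries (morpholin-3-yl)methyl in place of 1-acetylpiperidin-4-yl on an amide-type nitrogen. Within the data shown here, the only measured step that changes a single place, a 1.3-fold higher number from compound 1 to compound 2 (0.12 log units; within the scatter) and within the scatter, replaced morpholin-4-yl with (1-methylpiperidin-3-yl)amino on a sulfonyl sulfur, so it bears on this change only loosely. On that basis the expected move in this assay stays within the scatter, an estimated 1.3-fold higher number from compound 3 to compound 4 (0.11 log units; within the scatter) and no more. For compound 4 the estimate is 0.15 h with an expected range from 0.07 h to 0.32 h across repeat measurements.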

Compound 4, half-life: > 1 h
Compound 4 was reported as a limit; the forecaster's own chance of this, stated with the estimate: 5%; middle value at least 6.6-fold (0.82 log units) away from the limit.
By their numbers in this assay, from the lowest: compound 3; then compounds 1 and 2 (each within the scatter of the next). At a limit, above all of these: compound 4.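

In this assay, within the data shown here, (morpholin-3-yl)methyl in place of 1-acetylpiperidin-4-yl on the amide-type nitrogen gives an at least 8.5-fold higher number from compound 3 to compound 4 (0.93 log units; beyond the scatter), whereas the only earlier step, a 1.3-fold higher number from compound 1 to compound 2 (0.12 log units; within the scatter), stayed within the scatter. As far as these compounds go, compound 4 is reported as a limit and not as a number, so the full size of this step stays unknown: the limit of > 1 h in this assay, at which 1 of the 4 values shown sits. This amide-type nitrogen is therefore a place where a single change of group can move the half-life well beyond the scatter.

Among these compounds, the one step changes several things at once, and it cannot say whether the loss of the acetyl group, the second hetero atom in the ring or the methyl link carries the difference. From the compounds shown here alone, how a free piperidin-4-yl or a (piperidin-4-yl)methyl group on the same nitrogen would read in this assay stays open.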